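The compounds below may be only part of what the source reports. "The series", "measured", "known", "first", "only" and "open" are said of these compounds alone.

In a functional assay on PC-3 cells (Homo sapiens) for inhibition, read by MTT assay, with a stated time of 48 h (on this read-out lower numbers stand for stronger inhibition and higher numbers for weaker inhibition), compound 1 (`O=C(CCCOC(=O)c1ccc2c(c1)no[n+]2[O-])NO`) gives 6580 nM, compound 2 (`O=C(CCCCOC(=O)c1ccc2c(c1)no[n+]2[O-])NO`) gives 12700 nM and compound 3 (`O=C(CCCCCOC(=O)c1ccc2c(c1)no[n+]2[O-])NO`) gives 12400 nM. Compound 3 therefore stands within the scatter of both other compounds. Compound 4 (`O=C(CCCCCCOC(=O)c1ccc2c(c1)no[n+]2[O-])NO`) extends the same chain: (hydroxycarbamoyl)methyl in place of hydroxycarbamoyl on a saturated chain carbon, five bonds along the chain from an oxygen next to a carbonyl group. In words, this places (hydroxycarbamoyl)methyl in place of hydroxycarbamoyl on a saturated chain carbon, five bonds along the chain from an oxygen next to a carbonyl group. Earlier chain extensions gave a 1.9-fold higher number from compound 1 to compound 2 (0.29 log units; within the scatter), a 1.0-fold lower number from compound 2 to compound 3 (0.01 log units; within the scatter) and a 1.9-fold higher number from compound 1 to compound 3 (0.28 log units; within the scatter). None of these steps leaves the scatter, so no step beyond it is expected in this assay. The expected step is a 1.1-fold lower number from compound 3 to compound 4 (0.05 log units; within the scatter). The estimate for compound 4 is 11000 nM, with an expected range of 5000 nM to 22000 nM.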

Compound 4, half-maximal inhibitory concentration: 950 nM
Beside the measured number, compound 4's estimate is 12-fold (1.06 log units) above it, outside the stated range (below it).
By their numbers in this assay, from the lowest: compound 4; then compounds 1, 3 and 2 (each within the scatter of the next).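

In this assay the longest chain shown breaks away from the others: a 13-fold lower number from compound 3 to compound 4 (1.12 log units; beyond the scatter) and a 13-fold lower number from compound 2 to compound 4 (1.13 log units; beyond the scatter) stand with a 6.9-fold lower number from compound 1 to compound 4 (0.84 log units; beyond the scatter) as steps beyond the scatter. Lengthening this chain therefore has no single effect, and what it does depends on the chain it starts from: the same change on two cores in this assay, a 1.9-fold higher number (0.29 log units; within the scatter) from compound 1 to compound 2 and a 13-fold lower number (1.12 log units; beyond the scatter) from compound 3 to compound 4, 25-fold (1.40 log units) apart, beyond the scatter of two such steps. The larger extension shows the same split: the same change on two cores in this assay, a 1.9-fold higher number (0.28 log units; within the scatter) from compound 1 to compound 3 and a 13-fold lower number (1.13 log units; beyond the scatter) from compound 2 to compound 4, 25-fold (1.40 log units) apart, beyond the scatter of two such steps.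

The compounds shown leave open whether a longer chain would keep this low number or lose it. They also leave open whether a carboxylic acid in place of hydroxycarbamoyl would give a similar result on the chain of compound 4.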